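This account rests on a few compounds, and the source may have more. Where it says the series, first, only, none or still open, it means among the compounds named here.

Three measured compounds share one core and differ only in the aryl group carried by the amine nitrogen in the ring. Compound 1 `CCCc1nc(-c2ccccc2)c(CNCCN2CCN(c3ccc(C(F)(F)F)cc3)CC2)o1` gives 1300 nM in an assay on HEK293 cells for inhibition of Voltage-dependent T-type calcium channel subunit alpha-1G (Homo sapiens), read by patch clamp; a higher number here means a weaker inhibitor, a lower number a stronger inhibitor. Compound 2 `CCCc1nc(-c2ccccc2)c(CNCCN2CCN(c3cccc(F)c3)CC2)o1` gives 3350 nM in this assay, a change of a 2.6-fold higher number from compound 1 to compound 2 (0.41 log units; beyond the scatter). Compound 3 `CCCc1nc(-c2ccccc2)c(CNCCN2CCN(c3ccccc3C)CC2)o1` gives 4300 nM in this assay; this is the highest of the three numbers, but the nearer step is only a 1.3-fold higher number from compound 2 to compound 3 (0.11 log units; within the scatter), while the gap from compound 1 is a 3.3-fold higher number from compound 1 to compound 3 (0.52 log units; beyond the scatter).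

Compound 4 `CCCc1nc(-c2ccccc2)c(CNCCN2CCN(c3ccccc3)CC2)o1` differs from compound 3 by hydrogen in place of methyl on an aromatic carbon. Within the data shown here, no measured step removes a group from the aryl ring in this way; the nearest guidance is that exchanging one aryl group for another moved this assay by a 2.6-fold higher number from compound 1 to compound 2 (0.41 log units; beyond the scatter) and a 3.3-fold higher number from compound 1 to compound 3 (0.52 log units; beyond the scatter), and that exchanging 3-fluorophenyl for 2-methylphenyl moved it by a 1.3-fold higher number from compound 2 to compound 3 (0.11 log units; within the scatter). Since the two aryl groups without trifluoromethyl sit close together, removing the methyl from compound 3 is expected to give a step of a 1.2-fold lower number from compound 3 to compound 4 (0.08 log units; within the scatter), likely not beyond the scatter. For compound 4 the expected value in this assay is therefore 3600 nM, with a range from 1500 nM to 9000 nM.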

Compound 4, half-maximal inhibitory concentration: 10300 nM
Compound 4: the middle estimate sits 2.9-fold (0.46 log units) below what was measured; the measured number lies above the stated range.
By their numbers in this assay, from the lowest: compound 1; then compounds 2 and 3 (each within the scatter of the next); then compound 4.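

Among these compounds, compound 4 carries the plain phenyl that the earlier compounds lacked, and so gives them a reference point: in this assay, replacing each aryl substituent with hydrogen gives a 2.4-fold higher number from compound 3 to compound 4 (0.38 log units; beyond the scatter), then a 3.1-fold higher number from compound 2 to compound 4 (0.49 log units; beyond the scatter), and a 7.9-fold higher number from compound 1 to compound 4 (0.90 log units; beyond the scatter). The earlier compounds shown here only exchanged one substituted aryl group for another, whereas these steps show that all three substituted compounds are stronger inhibitors than compound 4, with none of the four going against this pattern. Nothing available here explains why the unsubstituted phenyl stands apart from the others.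

Each substituent appears at only one place on the aryl ring, so these compounds cannot separate the contribution of the group from that of its place, and the steps to compound 4 cannot show whether methyl, fluoro or trifluoromethyl would keep the same order if moved. As far as these compounds go, it also remains open whether a methoxy group or a chlorine atom on that ring would give a lower number than hydrogen, and whether the pattern would hold with a longer chain on the shared core.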